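Replacing the sulfonyl aryl group: from compound 2 to compound 4

The source may report more compounds than this note shows. Statements on the series, on what has been measured and on what is new or still open speak of the compounds shown alone.

Of the compounds shown here, three share one core and have been measured in an assay on isolated protein for displacement of a labelled ligand from metabotropic glutamate receptor 5 (Homo sapiens), with a stated time of 60 min, tested at 1 uM; a higher number here means more inhibition at the concentration tested (going by the name of the read-out), a lower number less inhibition. Compound 1 `CC1CCN(c2c(S(=O)(=O)c3ccc(F)c(Cl)c3)cnc3cc(F)ccc23)CC1` gives 94%, compound 2 `Cc1ccc(S(=O)(=O)c2cnc3cc(F)ccc3c2N2CCC(C)CC2)cc1Cl` gives 93%, and compound 3 `Cc1cc(C)cc(S(=O)(=O)c2cnc3ccc(C)cc3c2N2CCC(C)CC2)c1` gives 80%. Compound 2 thus stands second highest of the three numbers; compound 1 lies within the scatter of it, while compound 3 lies beyond the scatter below it.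

Within the data shown here, the only single-point step measured so far, a number 1 percentage points lower from compound 1 to compound 2 (within the scatter), lies within the scatter, and it sits on the core rather than on the aryl group attached to the sulfonyl sulfur. Compound 4 `CC1CCN(c2c(S(=O)(=O)c3ccc(F)cc3)cnc3cc(F)ccc23)CC1` has not yet been measured. It differs from compound 2 in one place: 4-fluorophenyl in place of 3-chloro-4-methylphenyl on a sulfonyl sulfur. Among the measured compounds shown here, no measured step touches this group alone, so the only guide is that compound 3, carrying a different aryl group there together with a second change, gives a lower number than compound 2. Compound 4 is therefore expected to give 85%, within 70% to 97%, a step from compound 2 to compound 4 estimated as a number 8 percentage points lower from compound 2 to compound 4 (within the scatter).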

Compound 4, a percentage reported as inhibition, at one concentration (the size of the read-out at that concentration, not a potency): 74.5%
Compound 4: the middle estimate sits 10.5 percentage points above what was measured, and the stated range covers the measured number.
By their numbers in this assay, from the lowest: compounds 4 and 3 (each within the scatter of the next); then compounds 2 and 1 (each within the scatter of the next).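

In this assay, among these compounds, the aryl group on the sulfonyl sulfur proves sensitive to change: 4-fluorophenyl in place of 3-chloro-4-methylphenyl gives a number 18.5 percentage points lower from compound 2 to compound 4 (beyond the scatter) and so falls beyond the scatter, which no single-place step had done before. The chloro group appears to account for the drop, since hydrogen in its place on an aromatic carbon gives a number 19.5 percentage points lower from compound 1 to compound 4 (beyond the scatter) while methyl in place of fluoro gives only a number 1 percentage points lower from compound 1 to compound 2 (within the scatter) and stays within the scatter. Nothing available explains this loss.

As far as these compounds go, whether a bromo or methoxy group in place of the chloro would hold the number remains open. So does whether the same step would appear on a core carrying something other than the 4-methylpiperidine-bearing arrangement shared by these compounds, and a reading at one concentration gives no potency.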